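Diaryl ether variation and cytotoxicity in the thymine-piperidine series

The compounds below may be only part of what the source reports. "The series", "measured", "known", "first", "only" and "open" are said of these compounds alone.

Compound 1 `Cc1cn(C2CCN(Cc3cccc(Oc4ccc(Cl)cc4)c3)CC2)c(=O)[nH]c1=O` is the reference point. In an ADME assay on MRC5 cells (Homo sapiens) for cytotoxicity, read by fluorescence and resazurin assay, with a stated time of 3 days (a higher number here means a weaker inhibitor, a lower number a stronger inhibitor), compound 1 gives 25100 nM, the highest of the two numbers in hand. Its nearest neighbour is compound 2 `Cc1cn(C2CCN(Cc3cccc(Oc4cc(Cl)cc(Cl)c4)c3)CC2)c(=O)[nH]c1=O`, which in this assay gives 6730 nM; the step of a 3.7-fold lower number from compound 1 to compound 2 (0.57 log units; beyond the scatter) is beyond the scatter. Compound 3 `Cc1cn(C2CCN(Cc3cccc(Oc4cccc(F)c4)c3)CC2)c(=O)[nH]c1=O` in this assay reaches only the limit > 64000 nM. The steps of an at least 2.5-fold higher number from compound 1 to compound 3 (0.40 log units; beyond the scatter) and an at least 9.5-fold higher number from compound 2 to compound 3 (0.97 log units; beyond the scatter) both run toward higher numbers when the 3-fluorophenyl group replaces a chlorinated ring.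

Compound 4 `Cc1cn(C2CCN(Cc3cccc(Oc4ccccn4)c3)CC2)c(=O)[nH]c1=O` is not yet measured. It differs from compound 1 by pyridin-2-yl in place of 4-chlorophenyl on an oxygen on an aromatic ring. The two steps that bear on it, a 3.7-fold lower number from compound 1 to compound 2 (0.57 log units; beyond the scatter) and an at least 2.5-fold higher number from compound 1 to compound 3 (0.40 log units; beyond the scatter), show that removing chlorine from the aryl ether moves the number upward, while adding chlorine moves it downward. Compound 4 also loses the chlorine of compound 1, so a modest rise is expected, with some chance that only the limit of > 64000 nM in this assay, at which 1 of the 3 values shown sits, is reported. Compound 4 is therefore estimated at 45000 nM, between 20000 nM and 100000 nM, which means an expected step of a 1.8-fold higher number from compound 1 to compound 4 (0.25 log units; within the scatter).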

Compound 4, half-maximal inhibitory concentration: > 64000 nM
Compound 4 was reported as a limit; the forecaster's own chance of this, stated with the estimate: 35%; middle value at least 1.4-fold (0.15 log units) from the limit.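

In this assay, the change from 4-chlorophenyl to pyridin-2-yl gives an at least 2.5-fold higher number from compound 1 to compound 4 (0.40 log units; beyond the scatter), and the dichlorinated ring gives way with an at least 9.5-fold higher number from compound 2 to compound 4 (0.97 log units; beyond the scatter); both steps rest on a limit, not a number, for compound 4. Going by these compounds alone, on the oxygen on an aromatic ring, a ring with a ring nitrogen and no chlorine thus joins the 3-fluorophenyl group at the top of the range, so among the four compounds only the chlorinated rings give readable numbers, with no compound going against this. The step from compound 3 to compound 4 cannot be read, and the two now share this ceiling: the limit of > 64000 nM in this assay, at which 2 of the 4 values shown sit.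

Going by these compounds, whether the rise follows the loss of chlorine or the entry of the ring nitrogen stays open, and a chloropyridin-2-yl ring would separate the two. On these data alone, how a methoxy group, an amine or a carboxylic acid on this ring would read also remains open.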